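This account rests on a few compounds, and the source may have more. Where it says the series, first, only, none or still open, it means among the compounds named here.

In a functional assay on A549 cells (Homo sapiens) for inhibition, read by MTT assay, with a stated time of 48 h (a lower number here means a stronger inhibitor, a higher number a weaker inhibitor), compound 1 (`C(=C/c1nc2ccccn2c1Sc1ccccc1)\c1ccccc1`) gives 16300 nM, compound 2 (`CSc1ccc(-c2nc3ccccn3c2Sc2ccccc2)cc1`) gives 13600 nM and compound 3 (`c1ccc(Sc2c(-c3cccs3)nc3ccccn23)cc1`) gives 16900 nM, so compound 3 stands level with the other two. Compound 4 (`Clc1ccc(Sc2c(-c3cccs3)nc3ccccn23)cc1`) differs from compound 3 in one place: chloro in place of hydrogen on an aromatic carbon. The measured steps all exchange a different group: a 1.2-fold lower number from compound 1 to compound 2 (0.08 log units; within the scatter), a 1.0-fold higher number from compound 1 to compound 3 (0.02 log units; within the scatter) and a 1.2-fold higher number from compound 2 to compound 3 (0.09 log units; within the scatter), each within the scatter. None of them measures this change directly, so only a small step in this assay is expected, with no firm direction beyond the scatter. The expected change is a 1.3-fold lower number from compound 3 to compound 4 (0.10 log units; within the scatter). Compound 4 is estimated at 13500 nM, with an expected range of 6500 nM to 27000 nM.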

Compound 4, half-maximal inhibitory concentration: 69800 nM
Beside the measured number, compound 4's estimate is 5.2-fold (0.71 log units) below it; the whole stated range lies below it.
By their numbers in this assay, from the lowest: compounds 2, 1 and 3 (each within the scatter of the next); then compound 4.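

In this assay, going by these compounds alone, the change from phenyl to 4-chlorophenyl gives a 4.1-fold higher number from compound 3 to compound 4 (0.62 log units; beyond the scatter) and so makes compound 4 a weaker inhibitor, whereas the earlier steps, which exchanged a different group, all stayed within the scatter. This position on the phenyl ring therefore moves the number, and chloro moves it towards weaker inhibition. Nothing measured here explains this shift. Going by these compounds, whether fluoro, methoxy or an amine at this position would do the same stays open. So does whether chloro would act alike with 4-(methylsulfanyl)phenyl or 2-phenylethenyl in place of thiophen-2-yl.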